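From methyl to methoxy on compound 1

This account rests on a few compounds, and the source may have more. Where it says the series, first, only, none or still open, it means among the compounds named here.

In an in vitro ADME assay on microsomes from liver (Homo sapiens) for pharmacokinetics, read by LC-MS (a lower number here means slower removal, a higher number faster removal of the compound), compound 1 (`Cc1cccc2c1nc(C)n2-c1ccc(C(=O)NC2CC2)s1`) gives 10 mL/min/kg as its clearance. Compound 2 (`Cc1cccc2nc(C)n(-c3ccc(C(=O)NC4CC4)s3)c12`) gives 6 mL/min/kg in the same test, so the two stand level within the usual scatter. Compound 3 (`COc1cccc2c1nc(C)n2-c1ccc(C(=O)NC2CC2)s1`) has methoxy in place of methyl on an aromatic carbon and otherwise matches compound 1. Going by the values given here, no measured pair shows this change, so only a small rise in this assay is expected, not beyond the scatter. The expected step is a 1.3-fold higher number from compound 1 to compound 3 (0.11 log units; within the scatter) in size. Compound 3 is estimated at 13 mL/min/kg (expected range 6 mL/min/kg to 26 mL/min/kg).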

Compound 3, clearance: 4 mL/min/kg
Compound 3: middle estimate off by 3.3-fold (0.51 log units), on the high side; measured number outside the range, below it.
By their numbers in this assay, from the lowest: compounds 3, 2 and 1 (each within the scatter of the next, the first and the last beyond it).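

In this assay, methoxy in place of methyl on this aromatic carbon gives a 2.5-fold lower number from compound 1 to compound 3 (0.40 log units; beyond the scatter). This shows that what sits at this position of the core can move clearance beyond the usual scatter, although the evidence rests on this single pair. Nothing available explains the fall. Still open, as far as these compounds go, is whether the effect is particular to methoxy, or whether ethoxy or an amine on the same carbon would shift the number similarly. From the compounds shown here alone, it is also open whether the same change would act alike elsewhere on the core.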